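Swapping the substituent on an aromatic nitrogen of compound 1

This account rests on a few compounds, and the source may have more. Where it says the series, first, only, none or still open, it means among the compounds named here.

Measured in a functional assay on A549 cells (Homo sapiens) for antiproliferative activity, read by MTT assay, with a stated time of 72 h; a lower number here means a stronger inhibitor, a higher number a weaker inhibitor:
- compound 1 `CCNC(=O)c1cc(Oc2ccc(NC(=O)c3nn(-c4ccccc4OC(F)(F)F)c(=O)cc3C)cc2)ccn1`: 5280 nM
- compound 2 `CCCNC(=O)c1cc(Oc2ccc(NC(=O)c3nn(-c4ccccc4C)c(=O)cc3C)cc2F)ccn1`: 25700 nM
- compound 3 `CNC(=O)c1cc(Oc2ccc(NC(=O)c3nn(-c4cccc(C(F)(F)F)c4)c(=O)cc3C)cc2F)ccn1`: 10200 nM

Among these three, compound 1 at 5280 nM lies within the scatter of compound 3 at 10200 nM and so cannot be separated from it. Compound 2 at 25700 nM has a higher number than compound 1, and that gap lies beyond the scatter.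

Compound 4 `CCNC(=O)c1cc(Oc2ccc(NC(=O)c3nn(-c4cccc(C(F)(F)F)c4)c(=O)cc3C)cc2)ccn1` is the next to be examined. It carries 3-(trifluoromethyl)phenyl in place of the 2-(trifluoromethoxy)phenyl of compound 1 on an aromatic nitrogen 3-(trifluoromethyl)phenyl in place of 2-(trifluoromethoxy)phenyl on an aromatic nitrogen and keeps the rest of the core of compound 1.

Among the measured compounds shown here, no measured pair isolates this exchange, so the evidence for it is indirect. Compound 3 also bears 3-(trifluoromethyl)phenyl, and its 10200 nM in this assay stays within the scatter of compound 1. A small move toward a higher number is therefore expected, possibly none beyond the scatter. The estimated change is a 1.4-fold higher number from compound 1 to compound 4 (0.15 log units; within the scatter) and is expected to stay within the scatter. Compound 4 is expected at about 7500 nM with an estimated range from 2800 nM to 20000 nM in this measurement.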

Compound 4, half-maximal inhibitory concentration: 10000 nM
Compound 4: middle estimate off by 1.3-fold (0.12 log units), on the low side; the range from low to high includes it.
By their numbers in this assay, from the lowest: compounds 1, 4 and 3 (each within the scatter of the next); then compound 2.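

In this assay, among the compounds shown here, placing 3-(trifluoromethyl)phenyl on the aromatic nitrogen in place of 2-(trifluoromethoxy)phenyl gives a 1.9-fold higher number from compound 1 to compound 4 (0.28 log units; within the scatter), and this is the first reading of this position with the rest of the core of compound 1 held constant. The two aryl groups cannot be separated in this assay, even though the entering group lacks the oxygen and the hydrogen-bond acceptor of the leaving group and carries its fluorinated substituent at a different ring position, so this exchange at the position leaves the antiproliferative reading on A549 cells unresolved rather than shifted. No measurement at hand offers any explanation for this outcome.

Going by these compounds, the exchange alters the substituent and its ring position together, so the effect of each alone remains unknown, and 2-(trifluoromethyl)phenyl or 3-(trifluoromethoxy)phenyl on the same core would be needed to pull them apart. On these data alone, it also remains open whether this position would accept a phenyl ring bearing an amine or a carboxylic acid, since both aryl groups compared here carry only fluorinated substituents.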